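The compounds below may be only part of what the source reports. "The series", "measured", "known", "first", "only" and "open" are said of these compounds alone.

Compound 1 `CC(C)C/N=c1\c(O)c(O)\c1=N/Cc1ccc(C#N)cc1` gives 10200 nM in a functional assay for inhibition, with Rattus norvegicus as the target; on this read-out higher numbers stand for weaker inhibition and lower numbers for stronger inhibition; this is the highest of the two numbers in the set. Its nearest neighbour is compound 3 `CCC(C)(C)/N=c1\c(O)c(O)\c1=N/Cc1ccc(F)cc1Cl`, whose value of 1500 nM is lower by a margin beyond the scatter. Compound 2 `N#Cc1ccc(CNc2c(N)c(=O)c2=O)cc1` returns only a limit, > 30000 nM, not a number; this is the limit of > 30000 nM in this assay, at which 1 of the 3 values shown sits.

Compound 4 `CC(C)(C)/N=c1\c(O)c(O)\c1=N/Cc1ccc(C#N)cc1` has not been measured in this assay. It differs from compound 1 by tert-butyl in place of isobutyl on a double-bonded nitrogen. Within the data shown here, no measured step of this kind exists in the set, so the expected change rests on compound 1 alone together with the lower reading of compound 3. A modest step toward a lower number is expected, a 2.0-fold lower number from compound 1 to compound 4 (0.31 log units; beyond the scatter), though one that may sit within the scatter. Compound 4 is estimated at 5000 nM, with a range from 1500 nM to 15000 nM.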

Compound 4, half-maximal inhibitory concentration: 270 nM
The estimate for compound 4 lay 19-fold (1.27 log units) above the measured number; measured number below the stated range.
By their numbers in this assay, from the lowest: compound 4; then compound 3; then compound 1. At a limit, above all of these: compound 2.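

In this assay, the position on the double-bonded nitrogen proves sensitive to how the alkyl group is joined: tert-butyl in place of isobutyl gives a 38-fold lower number from compound 1 to compound 4 (1.58 log units; beyond the scatter) with the same atoms. The earlier compounds shown here held no comparison that isolated this position, and here the group's atoms and counts stay unchanged while only their arrangement differs. Nothing measured here bears on the origin of this step.

Going by these compounds, whether a cyclohexyl group or a longer chain at this position would keep the lower number stays open. Also open, on these data alone, is whether a step of this size carries over to the chloro and fluoro end of compound 3.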